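Truncating the amino acid side chain on the sulfamoyl adenosine core

The source may report more compounds than this note shows. Statements on the series, on what has been measured and on what is new or still open speak of the compounds shown alone.

Measured in a functional assay on PBMC cells (Homo sapiens) for inhibition; a lower number here means a stronger inhibitor, a higher number a weaker inhibitor:
compound 1 `CSCC[C@H](N)C(=O)NS(=O)(=O)OC[C@H]1OC[C@@H](n2cnc3c(N)ncnc32)[C@H](O)[C@@H]1O` gives 5200 nM
compound 2 `Nc1ncnc2c1ncn2[C@@H]1CO[C@H](COS(=O)(=O)NC(=O)[C@@H]2CCCN2)[C@@H](O)[C@H]1O` gives 750 nM
compound 3 `N=C(N)NCCC[C@H](N)C(=O)NS(=O)(=O)OC[C@H]1OC[C@@H](n2cnc3c(N)ncnc32)[C@H](O)[C@@H]1O` gives 600 nM

Compound 3 has the lowest number of the three, but compound 2 sits within the scatter of it; only compound 1 is clearly apart, by an 8.7-fold lower number from compound 1 to compound 3 (0.94 log units; beyond the scatter). Compound 4 `C[C@H](N)C(=O)NS(=O)(=O)OC[C@H]1OC[C@@H](n2cnc3c(N)ncnc32)[C@H](O)[C@@H]1O` differs from compound 3 as follows: a hydrogen atom in place of a group of 6 heavy atoms (3 carbon, 3 nitrogen; no ring), on a saturated chain carbon, two bonds along the chain from an amine nitrogen and a carbonyl carbon. Among the compounds with values here, the steps that bear on this are an 8.7-fold lower number from compound 1 to compound 3 (0.94 log units; beyond the scatter) and a 6.9-fold lower number from compound 1 to compound 2 (0.84 log units; beyond the scatter), both showing that the side chain matters, whereas a 1.3-fold lower number from compound 2 to compound 3 (0.10 log units; within the scatter) is flat. Removing the chain entirely is expected to move in the opposite direction, toward or past compound 1, so compound 4 is expected at 4500 nM (range 1500 nM to 14000 nM), a step of a 7.5-fold higher number from compound 3 to compound 4 (0.88 log units; beyond the scatter).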

Compound 4, half-maximal inhibitory concentration: 300 nM
Beside the measured number, compound 4's estimate is 15-fold (1.18 log units) above it; measured number below the stated range.
By their numbers in this assay, from the lowest: compounds 4, 3 and 2 (each within the scatter of the next, the first and the last beyond it); then compound 1.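

In this assay, hydrogen in place of the group of 6 heavy atoms on this saturated chain carbon gives a 2.0-fold lower number from compound 3 to compound 4 (0.30 log units; within the scatter) and so leaves compound 4 within the scatter of compound 3, which shows that this long chain is not needed to hold the number. Hydrogen in place of (methylsulfanyl)methyl gives a 17-fold lower number from compound 1 to compound 4 (1.24 log units; beyond the scatter) as the largest new step, while 1-aminoethyl in place of pyrrolidin-2-yl gives a 2.5-fold lower number from compound 2 to compound 4 (0.40 log units; beyond the scatter) as a modest one. No available data explain these steps.

Still open, from the compounds shown here alone, is how a hydroxymethyl group or a carboxylic acid on this carbon would compare with compound 4. Also open, going by these compounds, is whether a simple propyl chain would follow compound 3 or compound 1.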